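Benzamide to cinnamamide on a chlorinated purine series

The source may hold more compounds than are shown below. What is called first, only, known or untested is meant among the compounds shown, and "the series" means these compounds.

Measured compounds:
- compound 1, `Nc1ccccc1NC(=O)c1ccc(Cn2cnc3c(NCc4ccccc4)nc(Cl)nc32)cc1`, gives 68.3% in a functional assay on HCT-116 cells (Homo sapiens) for antiproliferative activity, read by CCK-8 assay, with a stated time of 72 h, tested at 2 uM; a higher number here means a stronger effect of the compound at the concentration tested, a lower number a weaker effect
- compound 2, `CC1CCN(c2nc(Cl)nc3c2ncn3Cc2ccc(C(=O)Nc3ccccc3N)cc2)CC1`, gives 70.9% in this assay
- compound 3, `CN1CCN(c2nc(Cl)nc3c2ncn3Cc2ccc(C(=O)Nc3ccccc3N)cc2)CC1`, gives 71.6% in this assay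

Compound 1 holds the lowest of the three numbers, but its steps to the others, a number 2.6 percentage points higher from compound 1 to compound 2 (within the scatter) and a number 3.3 percentage points higher from compound 1 to compound 3 (within the scatter), stay within the scatter, as does a number 0.7 percentage points higher from compound 2 to compound 3 (within the scatter). The three measured compounds differ only on the aromatic carbon carrying benzylamino, 4-methylpiperidin-1-yl or 4-methylpiperazin-1-yl; that position looks insensitive in this assay.

Compound 4, `Nc1ccccc1NC(=O)/C=C/c1ccc(Cn2cnc3c(NCc4ccccc4)nc(Cl)nc32)cc1`, is not yet measured. It differs from compound 1 as follows: 2-((2-aminophenyl)carbamoyl)ethenyl in place of (2-aminophenyl)carbamoyl on an aromatic carbon. Among the measured compounds shown here, none of the measured steps touches this part of the molecule, so they give no direct guidance; they show only that compound 1 sits in a narrow band shared by its neighbours. For the measured compounds named here, with no comparable step in hand, the expected change a number 0.3 percentage points lower from compound 1 to compound 4 (within the scatter) is set at none beyond the scatter, with a wide range. Compound 4 is therefore estimated at 68%, expected between 48% and 85% in this assay.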

Compound 4, a percentage reported as inhibition, at one concentration (the size of the read-out at that concentration, not a potency): 2.85%
Compound 4: the middle estimate sits 65.2 percentage points above what was measured; the whole stated range lies above it.
By their numbers in this assay, from the lowest: compound 4; then compounds 1, 2 and 3 (each within the scatter of the next).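

Unlike the aromatic carbon carrying benzylamino, where the earlier swaps stayed within the scatter, the position para to a large group is highly sensitive in this assay: 2-((2-aminophenyl)carbamoyl)ethenyl in place of (2-aminophenyl)carbamoyl gives a number 65.5 percentage points lower from compound 1 to compound 4 (beyond the scatter). The entering group keeps the same aromatic ring and the same hydrogen-bond donor and acceptor counts, so the large step goes with the added ethenyl link, the only difference between the two groups. Nothing measured here accounts for the size of this step.

The ethenyl link is shown only with benzylamino, so it remains open whether the same loss appears with 4-methylpiperidin-1-yl or 4-methylpiperazin-1-yl on the shared core. Also open, as far as these compounds go, is how a saturated ethyl link or a methylene link would compare with the direct attachment in compound 1 and the ethenyl link in compound 4.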